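Two Changes on a Shared Core: Limits and One Number

A few compounds are considered here, and "the series" means these few. Any claim that something is new, unique, unknown or untested is made for them only; others in the source may bear on it.

compound 1, `CCCCCC(CCO)n1cnc2c(OC)ncnc21`: > 50000 nM
compound 2, `CCCCCC(CCO)n1cnc2c(NC)ncnc21`: > 50000 nM
compound 3, `CCCCCCCCCCCC(CCO)n1cnc2c(OC)ncnc21`: 9700 nM

Three compounds built on the same core were tested in a functional assay on SW480 cells (Homo sapiens) for antiproliferative activity, read by MTT assay, with a stated time of 48 h; a higher number here means a weaker inhibitor, a lower number a stronger inhibitor. For compound 1 the result is a limit of the assay, > 50000 nM. For compound 2 the result is likewise a limit, > 50000 nM. Compound 3 is the only one of the three that gives a number, 9700 nM; the other two results sit at the limit of > 50000 nM in this assay, at which 2 of the 3 values shown sit.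

Compound 3 differs from compound 1 by hexyl in place of hydrogen on a saturated chain carbon, six bonds along the chain from an aromatic nitrogen, and this change gives an at least 5.1-fold lower number from compound 1 to compound 3 (0.71 log units; beyond the scatter). Compound 2 differs from compound 1 by methylamino in place of methoxy on an aromatic carbon, and the size of that change is a step that the two limits leave unreadable from compound 1 to compound 2.

Compound 4 `CCCCCCCCCCCC(CCO)n1cnc2c(NC)ncnc21` has not yet been measured. Among the measured compounds shown here, it differs from compound 3 by methylamino in place of methoxy on an aromatic carbon, which is the same change, at the same place, as the one between compound 1 and compound 2. Because a step that the two limits leave unreadable from compound 1 to compound 2 cannot be sized, nothing measured here says whether this change helps or hurts, so compound 4 is expected to stay near compound 3, with a wide band around that guess. Compound 4 is estimated at 12000 nM, with a range from 4000 nM to 40000 nM. The step this estimate implies is expected to be a 1.2-fold higher number from compound 3 to compound 4 (0.09 log units; within the scatter).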

Compound 4, half-maximal inhibitory concentration: 12800 nM
For compound 4 the middle estimate is 1.1-fold (0.03 log units) below the measured one; the range from low to high includes it.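

In this assay, the exchange of methoxy for methylamino can be read on one core only, the one carrying the longer chain: a 1.3-fold higher number from compound 3 to compound 4 (0.12 log units; within the scatter). The hexyl change, read a second time on the methylamino core, gives an at least 3.9-fold lower number from compound 2 to compound 4 (0.59 log units; beyond the scatter), and it can be set beside its first reading: the same change on two cores in this assay, an at least 5.1-fold lower number (0.71 log units; beyond the scatter) from compound 1 to compound 3 and an at least 3.9-fold lower number (0.59 log units; beyond the scatter) from compound 2 to compound 4; the limit leaves it open whether they differ. The hexyl change therefore lowers the number on both cores, though neither size is known exactly, and the methoxy to methylamino exchange shows no step beyond the scatter on the longer chain, while the step between compound 1 and compound 2 cannot be read, so the compounds do not show whether that exchange carries over from one core to the other, because both results on the shorter chain are limits: the limit of > 50000 nM in this assay, at which 2 of the 4 values shown sit.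

The compounds shown leave open how far the trend with chain length runs, since a longer chain than the one in compound 3, or one of intermediate length, does not appear among them. They also leave open how this assay would read with ethoxy or dimethylamino in place of methoxy, or with an amine or a carboxylic acid in place of the hydroxyl.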